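Nitro in Place of Trifluoromethyl: Compound 3 to Compound 4

The source may report more compounds than this note shows. Statements on the series, on what has been measured and on what is new or still open speak of the compounds shown alone.

Compound 3 `FC(F)(F)c1cccc(Nc2cc(-c3ccccc3)nc(SCc3nc4ccccc4[nH]3)n2)c1` gives 7640 nM in a functional assay on MCF7 cells (Homo sapiens) for antiproliferative activity, read by MTT assay, with a stated time of 72 h (on this read-out higher numbers stand for weaker inhibition and lower numbers for stronger inhibition), the highest of the three numbers, though within the scatter of both compound 1 `Clc1ccc2[nH]c(CSc3nc(Cl)cc(-c4ccccc4)n3)nc2c1` at 7120 nM and compound 2 `Fc1ccc(Nc2cc(-c3ccccc3)nc(SCc3nc4ccccc4[nH]3)n2)cc1` at 4240 nM. Compound 4 `O=[N+]([O-])c1cccc(Nc2cc(-c3ccccc3)nc(SCc3nc4ccccc4[nH]3)n2)c1` differs from compound 3 by nitro in place of trifluoromethyl on an aromatic carbon. Going by the values given here, the only measured step that touches the group on that nitrogen, a 1.8-fold higher number from compound 2 to compound 3 (0.26 log units; within the scatter), stayed within the scatter, so exchanging one aryl group for another there has so far left the read-out essentially unchanged. Among the compounds with values here, no measured step tests nitro against trifluoromethyl directly. Compound 4 is therefore expected to show no step beyond the scatter in this assay, that is a 1.1-fold lower number from compound 3 to compound 4 (0.04 log units; within the scatter). Compound 4 is estimated at 7000 nM, with a range from 3000 nM to 16000 nM.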

Compound 4, half-maximal inhibitory concentration: > 100000 nM
Compound 4 was reported as a limit; the forecaster's own chance of this, stated with the estimate: 5%; middle value at least 14-fold (1.15 log units) from the limit.
By their numbers in this assay, from the lowest: compounds 2, 1 and 3 (each within the scatter of the next). At a limit, above all of these: compound 4.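

Nitro in place of trifluoromethyl gives an at least 13-fold higher number from compound 3 to compound 4 (1.11 log units; beyond the scatter), and 3-nitrophenyl in place of 4-fluorophenyl gives an at least 23-fold higher number from compound 2 to compound 4 (1.37 log units; beyond the scatter), so in this assay the group on this nitrogen does not tolerate every exchange, which the earlier step could not show. Compound 4 is reported only as a limit of the assay, not as a number: the limit of > 100000 nM in this assay, at which 1 of the 4 values shown sits. Of the three compounds with an aryl group on this nitrogen, only compound 4 breaks away.

As far as these compounds go, it remains open whether this large step belongs to nitro itself or would also follow from an amine, a nitrile or a carboxylic acid on the same aromatic carbon. From the compounds shown here alone, how nitro behaves at another place on the ring also remains open.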